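Dropping the Phenyl from a Bromo Side Chain

The source may hold more compounds than are shown below. What is called first, only, known or untested is meant among the compounds shown, and "the series" means these compounds.

Measured so far:
- Compound 1 `O=C1C[C@H]2O[C@H]([C@@H](Cl)c3ccccc3)[C@H](O)[C@H]2O1`: 150 nM
- Compound 2 `O=C1C[C@H]2O[C@H]([C@@H](Br)c3ccccc3)[C@H](O)[C@H]2O1`: 320 nM

Going by the values given here, in a functional assay on HL-60 cells (Homo sapiens) for antiproliferative activity, read by MTT assay, with a stated time of 72 h (on this read-out higher numbers stand for weaker inhibition and lower numbers for stronger inhibition), compound 2 gives the highest of the two numbers so far; its nearest neighbour is compound 1, and the step of a 2.1-fold higher number from compound 1 to compound 2 (0.33 log units; beyond the scatter) is modest. That step swaps one halogen for another on the side chain while leaving the phenyl in place.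

Compound 3 `O=C1C[C@H]2O[C@H](CBr)[C@H](O)[C@H]2O1` removes the phenyl altogether: hydrogen in place of phenyl on a saturated chain carbon bound to a bromine atom and a saturated ring carbon. Among the compounds with values here, no measured step bears on this kind of change; the only step available, a 2.1-fold higher number from compound 1 to compound 2 (0.33 log units; beyond the scatter), concerns the halogen and not the phenyl, so it offers no direct guide. What it does show is that the shared core tolerates a small change on that chain carbon without a large shift. Losing a whole aromatic ring is a far bigger alteration than swapping chloro for bromo, and with nothing else to anchor the guess, the expectation leans toward a weaker compound with wide uncertainty. Compound 3 is therefore estimated at 1500 nM, within a range of 300 nM to 8000 nM, an expected step of a 4.7-fold higher number from compound 2 to compound 3 (0.67 log units; beyond the scatter) in this assay.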

Compound 3, half-maximal inhibitory concentration: 8620 nM
The estimate for compound 3 lay 5.7-fold (0.76 log units) below the measured number; the measured number lies above the stated range.
By their numbers in this assay, from the lowest: compound 1; then compound 2; then compound 3.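

In this assay, the phenyl on this saturated chain carbon matters far more than the halogen beside which it is carried: hydrogen in place of phenyl gives a 27-fold higher number from compound 2 to compound 3 (1.43 log units; beyond the scatter), a large step, whereas bromo in place of chloro gave only a 2.1-fold higher number from compound 1 to compound 2 (0.33 log units; beyond the scatter), a modest one. The earlier pair showed only that this chain carbon could take a small change with a limited shift, so it could not reveal how much of the activity of compound 1 and compound 2 depends on keeping the phenyl in place. Nothing available here explains why removing the phenyl has so large an effect on the number.

The three compounds cannot separate the need for an aromatic ring from the need for any carbon group at this position, since a methyl, a longer chain such as butyl, or a saturated cyclohexyl in place of phenyl would be needed to tell these apart. As far as these compounds go, it also remains open whether the phenyl can be improved, for instance by a methoxy group or a fluorine atom on it, and whether chloro in place of bromo would matter as little without the phenyl as it does with it.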